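Chloro for methoxy on a pyrrolopyridine ether amide series

This account rests on a few compounds, and the source may have more. Where it says the series, first, only, none or still open, it means among the compounds named here.

Of the compounds shown here, three built on one shared core have so far been tested in a functional assay on A549 cells (Homo sapiens) for cytotoxicity, read by MTT assay, with a stated time of 72 h; on this read-out lower numbers stand for stronger inhibition and higher numbers for weaker inhibition. Compound 1 `Cc1ccc(-c2ccnc(C(=O)Nc3ccc(Oc4ccnc5[nH]ccc45)cc3)n2)cc1` gives 2380 nM in this assay. Compound 2 `O=C(Nc1ccc(Oc2ccnc3[nH]ccc23)cc1)c1nccc(-c2ccc(F)cc2)n1` is recorded in this assay as "not active" (no number reported), with no number attached to it. Compound 3 `COc1ccc(-c2cc(C(=O)Nc3ccc(Oc4ccnc5[nH]ccc45)cc3)ncn2)cc1` gives 4410 nM in this assay; its number and that of compound 1 lie within the usual scatter of each other, so nothing separates the two on the evidence at hand, and compound 2 contributes no number to compare.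

Compound 4 `O=C(Nc1ccc(Oc2ccnc3[nH]ccc23)cc1)c1cc(-c2ccc(Cl)cc2)ncn1` follows from compound 3 by a single change: chloro in place of methoxy on an aromatic carbon. Within the data shown here, no pair of measured compounds differs by this same change, so the size of the step cannot be read from the data; the nearest precedent is the halogen-bearing compound 2, whose outcome in this assay is uninformative as a number. With only one anchor to rest on, the expectation for the step from compound 3 to compound 4 in this assay is no change beyond the scatter, a 1.1-fold higher number from compound 3 to compound 4 (0.05 log units; within the scatter) being the estimated size. Compound 4 is accordingly expected to give about 5000 nM in this assay, within a range from 1500 nM to 20000 nM.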

Compound 4, half-maximal inhibitory concentration: 6530 nM
Compound 4: middle estimate off by 1.3-fold (0.12 log units), on the low side; the measured number falls inside the stated range.
By their numbers in this assay, from the lowest: compounds 1, 3 and 4 (each within the scatter of the next, the first and the last beyond it).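

In this assay, replacing 4-methoxyphenyl with 4-chlorophenyl gives a 1.5-fold higher number from compound 3 to compound 4 (0.17 log units; within the scatter), the first step measured at this position, and it leaves the two compounds indistinguishable on this read-out. Among these compounds, the earlier compounds offered no pair differing in one place, so this is the first direct sign that chloro can stand in for methoxy on this aromatic carbon, para to a large group, with a number still recorded: compound 4 gives 6530 nM. No measurement is at hand that would explain why the two compounds read alike.

Still open, from the compounds shown here alone, is whether an amine, a hydroxyl or a carboxylic acid on this aromatic carbon, or a longer chain such as ethoxy or butoxy, would produce a step beyond the scatter, since methoxy and chloro alone span too little to define what the position tolerates. Also open, going by these compounds, is whether the same exchange would behave alike on the core of compound 1 or compound 2, which differ from compound 3 and compound 4 in more than one place and so cannot be read against this step.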